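Same swap, different core: a topoisomerase inhibition estimate

The source may report more compounds than this note shows. Statements on the series, on what has been measured and on what is new or still open speak of the compounds shown alone.

Measured compounds:
Compound 1 `Oc1cccc(-c2cc(-c3ccsc3)cc(-c3cccc(O)c3)n2)c1` gives 59.2% in an assay on isolated protein for inhibition of DNA topoisomerase 1 (Homo sapiens), with a stated time of 30 min, tested at 100 uM; on this read-out higher numbers stand for a stronger effect at the one concentration tested and lower numbers for a weaker effect.
Compound 2 `Oc1ccc(-c2cc(-c3ccsc3)cc(-c3cccc(O)c3)n2)cc1` gives 17.1% in this assay.
Compound 3 `Oc1cccc(-c2cc(-c3cccnc3)cc(-c3ccccc3O)n2)c1` gives 1.9% in this assay.

Compound 1 and compound 2 differ in one place: 4-hydroxyphenyl in place of 3-hydroxyphenyl on an aromatic carbon. This swap brought a number 42.1 percentage points lower from compound 1 to compound 2 (beyond the scatter), a step far beyond the scatter of repeated measurements.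

Compound 4 `Oc1ccc(-c2cc(-c3cccnc3)cc(-c3ccccc3O)n2)cc1` has not yet been measured. It stands to compound 3 as compound 2 stands to compound 1: 4-hydroxyphenyl in place of 3-hydroxyphenyl on an aromatic carbon. The two cores, however, are not the same; how the core of compound 3 differs from that of compound 1 is not broken down here. The surroundings of the exchanged group also differ: in compound 1 the site is meta to a 3-hydroxyphenyl group and meta to a thiophen-3-yl group, while in compound 3 it is meta to a 2-hydroxyphenyl group and meta to a pyridin-3-yl group. The change is therefore the same kind of change, not the same change.

Compound 3 is the lowest of the three measured numbers, and its value of 1.9% leaves almost no room for a further fall. Within the data shown here, a step as large as the one seen from compound 1 to compound 2 cannot repeat here. For compound 4 a step of a number 0.1 percentage points higher from compound 3 to compound 4 (within the scatter) is expected, essentially flat. The estimate for compound 4 is 2%, with a likely range from -5% to 12%.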

Compound 4, a percentage reported as inhibition, at one concentration (the size of the read-out at that concentration, not a potency): 1.5%
For compound 4 the middle estimate is 0.5 percentage points above the measured one; low and high end bracket the measured number.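

In this assay, putting 4-hydroxyphenyl in place of 3-hydroxyphenyl gave a number 0.4 percentage points lower from compound 3 to compound 4 (within the scatter), so the large fall seen on the core of compound 1 did not appear on the core of compound 3, and the two steps differ clearly: the same change on two cores in this assay, a number 42.1 percentage points lower (beyond the scatter) from compound 1 to compound 2 and a number 0.4 percentage points lower (within the scatter) from compound 3 to compound 4, 41.7 percentage points apart, beyond the scatter of two such steps This shows that, across these two pairs, the result of this swap cannot simply be carried from one core to another, and a large step on one core did not predict a large step on the other. It does not show that the swap is harmless on the second core, since compound 3 starts at only 1.9% and a weak starting compound leaves almost no room for a fall; nor does it show why the pairs differ, since one core carries thiophen-3-yl with 3-hydroxyphenyl and the other pyridin-3-yl with 2-hydroxyphenyl, and these two differences are not separated here.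

The compounds shown leave open which of those two differences matters, and how the swap behaves on a core pairing pyridin-3-yl with 3-hydroxyphenyl. They also leave open what an amine or a methoxy group would do in the place of the hydroxyl group on the exchanged ring.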